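Replacing 4-methylphenyl with 3-methoxyphenyl on a shared core

The source may hold more compounds than are shown below. What is called first, only, known or untested is meant among the compounds shown, and "the series" means these compounds.

In a functional assay on SGC-7901 cells (Homo sapiens) for antiproliferative activity, read by MTT assay, with a stated time of 72 h (on this read-out lower numbers stand for stronger inhibition and higher numbers for weaker inhibition), two compounds sharing a core have been measured. Compound 1 (`CCOc1ccc(-c2ccc3ncn(-c4cc(OC)c(OC)c(OC)c4)c3c2)cc1`) gives 2970 nM, and compound 2 (`COc1cc(-n2cnc3ccc(-c4ccc(C)cc4)cc32)cc(OC)c1OC`) gives 200 nM, the lower of the two numbers. Among the measured compounds shown here, the only measured step, a 15-fold lower number from compound 1 to compound 2 (1.17 log units; beyond the scatter), is large and comes with methyl in place of ethoxy on an aromatic carbon.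

Compound 3 (`COc1cccc(-c2ccc3ncn(-c4cc(OC)c(OC)c(OC)c4)c3c2)c1`) keeps the core of compound 2 but carries 3-methoxyphenyl in place of 4-methylphenyl on an aromatic carbon. For the measured compounds named here, the single measured step bears on this change only in part. Compound 1, which has an oxygen-linked group in place of the methyl, reads 2970 nM, so a move towards a higher number seems likely. However, methoxy is not ethoxy and it sits at a different place on the phenyl group, and no measured pair tests such a move. Only part of that large step is therefore expected to carry over. The expected change is a 3.0-fold higher number from compound 2 to compound 3 (0.48 log units; beyond the scatter), towards weaker inhibition. For compound 3 the estimate is 600 nM, with an expected range of 150 nM to 2500 nM.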

Compound 3, half-maximal inhibitory concentration: 3310 nM
Estimate against measurement, compound 3: 5.5-fold (0.74 log units) below; the whole stated range lies below it.
By their numbers in this assay, from the lowest: compound 2; then compounds 1 and 3 (each within the scatter of the next).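

In this assay, moving to the 3-methoxyphenyl group gives a 17-fold higher number from compound 2 to compound 3 (1.22 log units; beyond the scatter), so this position is sensitive to more than the ethoxy group seen in compound 1. The direct comparison gives a 1.1-fold higher number from compound 1 to compound 3 (0.05 log units; within the scatter), so 3-methoxyphenyl and 4-ethoxyphenyl cannot be told apart here, and among these three compounds only compound 2, whose group carries no oxygen, gives a clearly lower number, with no compound going against that. No measurement shown here explains this difference.

Compound 3 differs from compound 2 both in the group on the phenyl ring and in where that group sits, so the effect of the oxygen cannot be separated from the effect of its place. From the compounds shown here alone, how a simple fluorine atom, an amine or a carboxylic acid on that phenyl ring would read remains open, and so does whether any group can give a lower number than the methyl of compound 2.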